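Chloro in place of fluoro, an unmeasured step

A few compounds are considered here, and "the series" means these few. Any claim that something is new, unique, unknown or untested is made for them only; others in the source may bear on it.

In a physicochemical assay for solubility, read by spectrophotometry, in phosphate buffer, measured as kinetic solubility, with a stated time of 18 h, at pH 7.4 (on this read-out higher numbers stand for higher solubility and lower numbers for lower solubility), compound 1 (`O=C(Nc1ccc(F)c(-c2nc3ccccc3o2)c1)c1cc([N+](=O)[O-])ccc1Cl`) gives 270 nM and compound 2 (`Cc1cc(NC(=O)c2cc([N+](=O)[O-])ccc2Cl)cc(-c2nc3ccccc3o2)c1O`) gives 90 nM on the same scale. Compound 3 (`O=C(Nc1ccc(F)c(-c2nc3ccccc3s2)c1)c1cc([N+](=O)[O-])ccc1Cl`) gives 490 nM in this assay and so stands within the scatter of compound 1, while the number of compound 2 lies lower and beyond the scatter. The next compound keeps the shared core of compound 3 and alters one substituent. Compound 4 (`O=C(Nc1ccc(Cl)c(-c2nc3ccccc3s2)c1)c1cc([N+](=O)[O-])ccc1Cl`) differs by chloro in place of fluoro on an aromatic carbon and this chloro in place of fluoro sits on an aromatic carbon, ortho to a 1,3-benzothiazol-2-yl group and para to a large group. Among the measured compounds shown here, no measured step exchanges these two groups, so the data give no direct guide to this change. For the measured compounds named here, the only measured step is a 1.8-fold higher number from compound 1 to compound 3 (0.26 log units; within the scatter) and it lies within the scatter, but it concerns 1,3-benzothiazol-2-yl in place of 1,3-benzoxazol-2-yl at another place. The expected change is a 1.2-fold lower number from compound 3 to compound 4 (0.09 log units; within the scatter) and no step beyond the scatter is foreseen in either direction. For compound 4 the estimated value is 400 nM with an expected range from 150 nM to 900 nM in this estimate.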

Compound 4, solubility: 410 nM
Compound 4: the middle estimate sits 1.0-fold (0.01 log units) below what was measured; the measured number falls inside the stated range.
By their numbers in this assay, from the lowest: compound 2; then compounds 1, 4 and 3 (each within the scatter of the next).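

At this place, on an aromatic carbon ortho to a 1,3-benzothiazol-2-yl group and para to a large group, chloro in place of fluoro gives a 1.2-fold lower number from compound 3 to compound 4 (0.08 log units; within the scatter) in this assay and so leaves compound 3 and compound 4 indistinguishable on this read-out. The earlier compounds held fluoro at this place throughout and offered only a 1.8-fold higher number from compound 1 to compound 3 (0.26 log units; within the scatter) for an exchange elsewhere, so this is the first reading of what a different halogen here does, and among the compounds shown, one halogen serves as well as the other on these numbers. Nothing available on these compounds offers an explanation for this result.

The compounds shown leave open whether a group other than a halogen at this place, such as a methoxy group, a nitrile, an amine or a carboxylic acid, would also stay within the scatter of compound 3. They also leave open whether chloro in place of fluoro would read the same way with the 1,3-benzoxazol-2-yl group of compound 1 in the neighbouring position named above.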